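Series notes: a further chloro step from compound 3

This account rests on a few compounds, and the source may have more. Where it says the series, first, only, none or still open, it means among the compounds named here.

Of the compounds shown here, three have been measured so far. Compound 1 `Clc1ccc(COc2ccc(/C=C/C(/C=C/c3ccccn3)=N/Oc3ncnc4ccccc34)cc2)cc1` gives in a functional assay on SMMC-7721 cells (Homo sapiens) for inhibition, read by MTT assay, with a stated time of 72 h, tested at 10 uM (a lower number here means a weaker effect, a higher number a stronger effect of the compound at the concentration tested), a value of 94.4%. Compound 2 `Clc1ccccc1COc1ccccc1/C=C/C(/C=C/c1ccccn1)=N/Oc1ncnc2ccccc12` gives in this assay a value of 96%. Compound 3 `Clc1ccc(COc2ccc(/C=C/C(/C=C/c3ccccn3)=N/Oc3ncnc4ccccc34)cc2)c(Cl)c1` gives in this assay a value of 89.6%. On these numbers compound 3 carries the lowest of the three readings, but its nearest neighbour compound 1 is within the scatter, and even the furthest, compound 2, is within the scatter, so nothing separates the three.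

Going by the values given here, the only measured step of one change is a number 4.8 percentage points lower from compound 1 to compound 3 (within the scatter), a chloro in place of hydrogen on an aromatic carbon that left the read-out essentially where it was.

Compound 4 `Clc1ccc(COc2ccc(/C=C/C(/C=C/c3ccccn3)=N/Oc3ncnc4cc(Cl)ccc34)cc2)c(Cl)c1` has not yet been measured. It differs from compound 3 by chloro in place of hydrogen on an aromatic carbon. Among the compounds with values here, the one measured step of the same kind, the chloro added from compound 1 to compound 3, stayed within the scatter, so no step beyond the scatter is expected here either, in either direction. The expected change is a number 1.6 percentage points lower from compound 3 to compound 4 (within the scatter). For compound 4 the estimate in this assay is therefore 88%, with a range from 76% to 96%.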

Compound 4, a percentage reported as inhibition, at one concentration (the size of the read-out at that concentration, not a potency): 23.6%
The estimate for compound 4 lay 64.4 percentage points above the measured number, outside the stated range (below it).
By their numbers in this assay, from the lowest: compound 4; then compounds 3, 1 and 2 (each within the scatter of the next).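

In this assay the chloro change is no longer silent: at the new position the step is a number 66 percentage points lower from compound 3 to compound 4 (beyond the scatter) and stands as the only one shown beyond the scatter, while the same kind of change elsewhere in the series gave a number 4.8 percentage points lower from compound 1 to compound 3 (within the scatter) and stayed within it. The kind of change alone therefore does not set the size of the step in these two pairs, and where the chloro enters matters, here on the quinazolin-4-yl part, which compounds 1, 2 and 3 all carry without a substituent. Nothing on hand bears on why the read-out drops so far at this position.

Open, going by these compounds, is whether the drop belongs to chloro itself or to any group on this carbon, which a fluoro, a methoxy or an amine in place of the chloro of compound 4 would begin to separate. Going by these compounds alone, also open is whether 7-chloroquinazolin-4-yl has the same effect with the other side chains, such as the one in compound 2, and how the drop at a single concentration translates into potency.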